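The compounds below may be only part of what the source reports. "The series", "measured", "known", "first", "only" and "open" are said of these compounds alone.

Measured in a functional assay on KYSE-410 cells (Homo sapiens) for antiproliferative activity, read by MTT assay, with a stated time of 72 h; a lower number here means a stronger inhibitor, a higher number a weaker inhibitor:
- compound 1 `CC(C)(C)c1ccc(-c2ccc3c(C(=O)Nc4cccc(F)c4)cc(=O)[nH]c3c2)cc1`: > 20000 nM (a limit of the assay, not a number)
- compound 2 `COc1ccc(-c2ccc3c(C(=O)Nc4cccc(F)c4)cc(=O)[nH]c3c2)cc1`: 18000 nM
- compound 3 `O=C(Nc1cccc(F)c1)c1cc(=O)[nH]c2cc(-c3ccsc3)ccc12`: 4300 nM

Compound 3 has the lower of the two actual numbers in this assay, and compound 2 is its nearest neighbour, as a 4.2-fold lower number from compound 2 to compound 3 (0.62 log units; beyond the scatter) shows. Compound 4 `O=C(Nc1cccc(F)c1)c1cc(=O)[nH]c2cc(C3CC3)ccc12` changes the same position: cyclopropyl in place of thiophen-3-yl on an aromatic carbon. Cyclopropyl stands in place of thiophen-3-yl on an aromatic carbon of a six-membered aromatic ring of carbon only.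

Among the measured compounds shown here, three measured steps bear on this. Replacing the substituted phenyl groups with thiophen-3-yl gave a 4.2-fold lower number from compound 2 to compound 3 (0.62 log units; beyond the scatter) and an at least 4.6-fold lower number from compound 1 to compound 3 (0.66 log units; beyond the scatter), the latter only a floor. The exchange between the two phenyl substituents gave an at least 1.1-fold lower number from compound 1 to compound 2 (0.04 log units; that floor lies within the scatter). All three compounds carry an aromatic group at this position, so none measures the effect of a non-aromatic ring there. The steps are modest, which gives no basis for expecting a large change, and no direction is firmly supported. The expected change is small and not clearly beyond the scatter, at a 1.4-fold higher number from compound 3 to compound 4 (0.14 log units; within the scatter), with a slight allowance for a higher number.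

For compound 4 the estimated value in this assay is 6000 nM, with an expected range of 2200 nM to 17000 nM.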

Compound 4, half-maximal inhibitory concentration: > 20000 nM
Compound 4: only a limit was reported; the forecaster's own chance of this, stated with the estimate: 12%; middle value at least 3.3-fold (0.52 log units) from the limit.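

In this assay, cyclopropyl is the only non-aromatic ring at this position among the compounds shown, and replacing thiophen-3-yl with it gives an at least 4.6-fold higher number from compound 3 to compound 4 (0.66 log units; beyond the scatter), so the activity of compound 3 does not carry over to a small carbon-only ring. Replacing 4-methoxyphenyl with cyclopropyl gives an at least 1.1-fold higher number from compound 2 to compound 4 (0.04 log units; that floor lies within the scatter), a floor that does not separate the two groups, which leaves thiophen-3-yl as the only group here with a clear advantage over the others shown. Compound 4 gives only a limit of the assay, as does compound 1, and the step between them cannot be read: the limit of > 20000 nM in this assay, at which 2 of the 4 values shown sit.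

Going by these compounds, how far the true value of compound 4 lies past that limit remains open, as does whether the gain with thiophen-3-yl depends on the five-membered aromatic ring, its sulfur or the absence of a para substituent on a larger ring. Furan-3-yl, unsubstituted phenyl, pyridin-3-yl or a ring amine such as morpholine at this position would help separate these readings.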